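Swapping a benzylamino for a dichlorophenylthio group

The source may report more compounds than this note shows. Statements on the series, on what has been measured and on what is new or still open speak of the compounds shown alone.

Within the data shown here, the three compounds measured so far share one core and differ only in the group on a single aromatic carbon. Compound 1 `Nc1cc(N)c2nc(-c3ccccc3)c(Oc3ccc(Cl)c(Cl)c3)nc2c1` carries a 3,4-dichlorophenoxy group and gives 3470 nM in a functional assay on RPMI8266 cells (Homo sapiens) for inhibition, read by sulforhodamine B assay, with a stated time of 48 h; a lower number here means a stronger inhibitor of growth, a higher number a weaker inhibitor of growth. Compound 2 `COc1ccc(CNc2nc3cc(N)cc(N)c3nc2-c2ccccc2)cc1OC` gives 2140 nM, and compound 3 `Nc1cc(N)c2nc(-c3ccccc3)c(NCc3ccc(F)cc3)nc2c1` gives 2510 nM. Compound 3 thus has the second highest of the three numbers, but both neighbours are close: a 1.4-fold lower number from compound 1 to compound 3 (0.14 log units; within the scatter) and a 1.2-fold higher number from compound 2 to compound 3 (0.07 log units; within the scatter), each a step within the scatter.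

Compound 4 `Nc1cc(N)c2nc(-c3ccccc3)c(Sc3ccc(Cl)c(Cl)c3)nc2c1` is not yet measured. It differs from compound 3 by (3,4-dichlorophenyl)sulfanyl in place of (4-fluorobenzyl)amino on an aromatic carbon. The measured step that bears most directly on this change is a 1.4-fold lower number from compound 1 to compound 3 (0.14 log units; within the scatter), which exchanged a 3,4-dichlorophenoxy group for the same (4-fluorobenzyl)amino group and stayed within the scatter. Among the measured compounds shown here, compound 4 returns to a 3,4-dichlorophenyl group, now joined through sulfur rather than oxygen, and no measured pair shows what that exchange of the linking atom does. The step from compound 3 to compound 4 is therefore expected to be small, a 1.3-fold higher number from compound 3 to compound 4 (0.11 log units; within the scatter), leaning toward the number of compound 1. Compound 4 is estimated at 3200 nM in this assay, with a range from 1300 nM to 8000 nM.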

Compound 4, concentration for 50% growth inhibition: 3800 nM
Estimate against measurement, compound 4: 1.2-fold (0.07 log units) below; the range from low to high includes it.
By their numbers in this assay, from the lowest: compounds 2, 3, 1 and 4 (each within the scatter of the next).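

The oxygen and sulfur links can now be compared directly: with the 3,4-dichlorophenyl group kept on the same aromatic carbon, there is a 1.1-fold higher number from compound 1 to compound 4 (0.04 log units; within the scatter) in this assay, so the linking atom makes no difference that can be told from the scatter in this pair. The wider exchange also stays within the scatter, with a 1.5-fold higher number from compound 3 to compound 4 (0.18 log units; within the scatter), even though (3,4-dichlorophenyl)sulfanyl lacks the hydrogen-bond donor of (4-fluorobenzyl)amino and brings sulfur and chlorine in place of nitrogen and fluorine. No measurement shown explains why these different groups give such similar numbers.

Every group shown at this position contains a six-membered aromatic ring of carbon only, so it remains open whether a plain amine, a carboxylic acid on a longer chain or a simple alkyl chain would move the number beyond the scatter. The phenyl group and the two amino groups on the shared core are also the same in these compounds, leaving open how much each contributes to growth inhibition.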